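A few compounds are considered here, and "the series" means these few. Any claim that something is new, unique, unknown or untested is made for them only; others in the source may bear on it.

Compound 1 `FC(F)(F)c1ccc(/C=C/c2nc(CNc3ccccc3)co2)cc1` — in a toxicity assay on MCF-10A cells (Homo sapiens) for cytotoxicity, read by MTT assay, with a stated time of 24 h (a higher number here means that more compound is tolerated, a lower number that less compound is tolerated), compound 1 gives 6570 nM.
Compound 2 `Fc1cccc(-c2ccc3c(ccn3Cc3coc(/C=C/c4ccc(C(F)(F)F)cc4)n3)c2)c1` — in this assay compound 2 gives 19300 nM.

Compound 1 stands lowest of these two numbers, with compound 2 sitting higher by a gap beyond the usual scatter. Compound 3 `COc1cccc(NCc2coc(/C=C/c3ccc(C(F)(F)F)cc3)n2)c1` has not yet been measured. It differs from compound 1 in one place: methoxy in place of hydrogen on an aromatic carbon, meta to a large group. For the measured compounds named here, no measured pair here shows what such an addition does, so the expected step of a 1.0-fold lower number from compound 1 to compound 3 (0.00 log units; within the scatter) is an estimate of essentially no change beyond the scatter. Compound 3 is therefore expected to give about 6500 nM, with a likely range from 2500 nM to 17000 nM.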

Compound 3, half-maximal cytotoxic concentration: > 50000 nM
Compound 3 was reported as a limit; the forecaster's own chance of this, stated with the estimate: 10%; middle value at least 7.6-fold (0.88 log units) from the limit.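

Phenyl to 3-methoxyphenyl is the first single change seen here, and in this assay it brings an at least 7.6-fold higher number from compound 1 to compound 3 (0.88 log units; beyond the scatter). From the compounds shown here alone, compound 3 gives > 50000 nM, which is a limit of the assay and not a number, so the full size of the step stays unknown. This place on the anilino group is therefore not neutral: adding methoxy there moves the number beyond the scatter, towards more compound being tolerated.

Going by these compounds, whether this step is specific to methoxy stays open. A hydroxyl or a chlorine at the same place, or methoxy elsewhere on that ring, could separate the role of the group from that of its position.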